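The compounds below may be only part of what the source reports. "The series", "measured", "known", "first", "only" and "open" are said of these compounds alone.

Series notes. The shared core is common to compound 1 `Cc1nn(-c2ncnc3nc[nH]c23)c2c1C(OCc1cc(F)cc3c1OCOC3)CC(=O)N2`, compound 2 `Cc1nn(-c2ncnc3nc[nH]c23)c2c1C(c1ccc(F)cc1Cl)CC(=O)N2` and compound 3 `CCC(C(=O)NC1CC(=O)Nc2c1c(C)nn2-c1ncnc2nc[nH]c12)c1ccccc1`; all three carry their variable part on the saturated ring carbon and have been run in a functional assay on HEK293 cells for agonist activity at G-protein coupled receptor 39 (Homo sapiens), read by scintillation proximity assay and inositol phosphate accumulation, with a stated time of 75 min, in the presence of a further agent that is not named here; on this read-out lower numbers stand for an effect already at smaller amounts and higher numbers for an effect only at larger amounts of compound. In this assay compound 1 gives 1.5 nM, compound 2 gives 9 nM and compound 3 gives 5 nM. Compound 2 holds the highest of the three numbers, though its value and that of compound 3 lie within the scatter of each other; the gap between compound 2 and compound 1 lies beyond the scatter. Among the measured compounds shown here, no pair of measured compounds differs in a single place, so no single step has been computed.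

The next compound is compound 4 `Cc1nn(-c2ncnc3nc[nH]c23)c2c1C(OC(=O)c1ccc(F)cc1)CC(=O)N2`, not yet measured in this assay. Relative to compound 2 the change is ((4-fluorophenyl)carbonyl)oxy in place of 2-chloro-4-fluorophenyl on a saturated ring carbon. For the measured compounds named here, no measured pair bears directly on this replacement. What the set shows is that varied groups on the saturated ring carbon have kept every compound in a narrow span, from compound 1 at 1.5 nM to compound 2 at 9 nM. The step of a 1.8-fold lower number from compound 2 to compound 4 (0.26 log units; within the scatter) is expected to be small, toward a lower number, and not clearly beyond the scatter. Compound 4 is estimated at 5 nM, with a range from 1.5 nM to 20 nM.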

Compound 4, half-maximal effective concentration: 4 nM
Compound 4: middle estimate off by 1.3-fold (0.10 log units), on the high side; low and high end bracket the measured number.
By their numbers in this assay, from the lowest: compound 1; then compounds 4, 3 and 2 (each within the scatter of the next, the first and the last beyond it).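

In this assay, among the compounds shown here, this is the first single-place comparison at the saturated ring carbon, and it gives a 2.3-fold lower number from compound 2 to compound 4 (0.35 log units; beyond the scatter), a modest step. The position therefore accepts more than an aryl group attached directly: ((4-fluorophenyl)carbonyl)oxy, with its carbonyl and 2 hydrogen-bond acceptors, takes the place of 2-chloro-4-fluorophenyl, which has none, and the number does not rise. The six-membered aromatic ring of carbon is present on both sides of the step, while the chlorine leaves and the two oxygens enter together, so this one step cannot assign the change to any single part of the replacement, and nothing measured here accounts for it.

The compounds shown leave open whether the aromatic ring is needed at all on the saturated ring carbon, a question that a carboxylic acid, a primary amine or a longer alkyl chain in that place would address. They also leave open how the chlorine and the carbonyloxy link each count separately, which would take 4-fluorophenyl on the same carbon and ((2-chloro-4-fluorophenyl)carbonyl)oxy to separate.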